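Swapping the piperidine substituent in compound 3

The compounds below may be only part of what the source reports. "The series", "measured", "known", "first", "only" and "open" are said of these compounds alone.

Three compounds share a core that carries an amide-linked propanamide and a methanesulfonamide, and differ in the amine on the aromatic carbon of the trifluoromethyl-bearing ring. Compound 1 `CCCN(CCC)c1nc(C(F)(F)F)ccc1CNC(=O)C(C)c1ccc(NS(C)(=O)=O)c(F)c1` gives 0.2 nM in a functional assay on CHO-K1 cells for antagonist activity at transient receptor potential cation channel subfamily V member 1 (Homo sapiens), read by FLIPR; on this read-out lower numbers stand for stronger inhibition and higher numbers for weaker inhibition. Among the compounds with values here, compound 2 `CC(C(=O)NCc1ccc(C(F)(F)F)nc1N1CCCCC1C)c1ccc(NS(C)(=O)=O)c(F)c1` gives 2.9 nM, and the change from a 15-fold higher number from compound 1 to compound 2 (1.16 log units; beyond the scatter) is the only single-point step among the measured pairs. Compound 3 `CC(C(=O)NCc1ccc(C(F)(F)F)nc1N1CCC(C(=O)c2ccc(F)cc2)CC1)c1ccc(NS(C)(=O)=O)c(F)c1` gives 3.9 nM; its number sits within the scatter of that of compound 2, and it is the highest of the three, well beyond the scatter from compound 1.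

Compound 4 `CC(C(=O)NCc1ccc(C(F)(F)F)nc1N1CCC(CN(C)C)CC1)c1ccc(NS(C)(=O)=O)c(F)c1` differs from compound 3 by (dimethylamino)methyl in place of (4-fluorophenyl)carbonyl on a saturated ring carbon. Within the data shown here, no measured step touches the substituent on the saturated ring, so the available data give no direct guide; the only measured step concerns the amine on the aromatic carbon. Since compound 2, with no large group on its ring, and compound 3 lie within the scatter of each other, the ring substituent appears to matter little here. Compound 4 is therefore expected to land near compound 3, with a 1.3-fold higher number from compound 3 to compound 4 (0.11 log units; within the scatter) expected to stay within the scatter. The estimate for compound 4 is 5 nM, expected between 1.5 nM and 20 nM.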

Compound 4, inhibition constant: 2.1 nM
Beside the measured number, compound 4's estimate is 2.4-fold (0.38 log units) above it; the measured number falls inside the stated range.
By their numbers in this assay, from the lowest: compound 1; then compounds 4, 2 and 3 (each within the scatter of the next).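

In this assay, the saturated ring carbon accepts (dimethylamino)methyl in place of (4-fluorophenyl)carbonyl, with no ring in the entering group, and the result is a 1.9-fold lower number from compound 3 to compound 4 (0.27 log units; within the scatter), so this exchange does not separate the two compounds. The new amine also stays level with 2-methylpiperidin-1-yl on the aromatic carbon, giving a 1.4-fold lower number from compound 2 to compound 4 (0.14 log units; within the scatter), while dipropylamino remains apart, with an 11-fold higher number from compound 1 to compound 4 (1.02 log units; beyond the scatter). Nothing available explains why the ring substituent changes so little or why dipropylamino stands apart.

Going by these compounds, it remains open whether a carboxylic acid or a primary amine on that saturated ring carbon, or a longer chain ending in dimethylamino, would stay level with compound 4. Also open, on these data alone, is whether an open-chain amine such as diethylamino on the aromatic carbon would stand with compound 1 or with compound 4.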